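The compounds below may be only part of what the source reports. "The series", "measured", "known", "first", "only" and "open" are said of these compounds alone.

In an ADME assay on MT4 cells (Homo sapiens) for cytotoxicity, read by MTT assay, with a stated time of 5 days (a lower number here means that less compound is tolerated, a higher number that more compound is tolerated), compound 1 `COc1cc2nc(SCC(=O)Nc3ccc(S(N)(=O)=O)cc3)nc(Nc3c(Cl)cc(/C=C/C#N)cc3Cl)c2cc1OC` gives 116000 nM. Compound 2 `COc1cc2nc([S+]([O-])CC(=O)Nc3ccccc3[N+](=O)[O-])nc(Nc3c(Cl)cc(/C=C/C#N)cc3Cl)c2cc1OC` shows > 199000 nM, which is a limit of the assay and not a number, and the evidence so far records (the limit of > 199000 nM in this assay, at which 1 of the 2 values shown sits). Compound 3 `COc1cc2nc([S+]([O-])CC(=O)Nc3cccc([N+](=O)[O-])c3)nc(Nc3c(Cl)cc(/C=C/C#N)cc3Cl)c2cc1OC` has not yet been measured and differs from compound 2 in one place: 3-nitrophenyl in place of 2-nitrophenyl on an amide-type nitrogen, with 3-nitrophenyl in place of 2-nitrophenyl on an amide-type nitrogen. Within the data shown here, no measured pair shows this change, so no direction can be favoured and nothing beyond the usual scatter is expected. The estimated step is an at least 1.1-fold lower number from compound 2 to compound 3 (0.06 log units; that floor lies within the scatter). For compound 3 the expected value is 170000 nM, with an estimated range of 70000 nM to 280000 nM.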

Compound 3, half-maximal cytotoxic concentration: >= 83200 nM
Compound 3: no number, only a limit; the forecaster's own chance of this, stated with the estimate: 50%; the middle value is on the limit's open side.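

In this assay, among these compounds, compound 2 and compound 3 each give only a limit of the assay, not a number, and no step between them can be read. The compounds shown leave open whether 3-nitrophenyl in place of 2-nitrophenyl on an amide-type nitrogen changes the tolerated concentration at all.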